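Methylamino in Place of Nitro on an Aromatic Carbon

A few compounds are considered here, and "the series" means these few. Any claim that something is new, unique, unknown or untested is made for them only; others in the source may bear on it.

In a functional assay on HT-29 cells (Homo sapiens) for antiproliferative activity, read by MTT assay, with a stated time of 72 h (on this read-out lower numbers stand for stronger inhibition of growth and higher numbers for weaker inhibition of growth), compound 1 `CC(=O)Nc1cc(OCC(C)C)nc(SCc2ccccc2)n1` gives 35700 nM as a measured number. Compound 2 `COc1cc(OC)n2cc(-c3ccc([N+](=O)[O-])cc3)nc2n1` stands only at a limit of the assay, > 100000 nM and not a number. Compound 3 `CNc1ccc(-c2cn3c(OC)cc(OC)nc3n2)cc1` has methylamino in place of nitro on an aromatic carbon, para to a large group (methylamino in place of nitro on an aromatic carbon). Going by the values given here, no measured step shows what this change does. A modest move toward stronger inhibition of growth is expected in this assay as an estimated at least 2.5-fold lower number from compound 2 to compound 3 (0.39 log units; beyond the scatter) and resting only on the level of compound 1 (35700 nM). The expected value for compound 3 is 40000 nM with an estimated range from 6000 nM to 100000 nM in this assay here.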

Compound 3, concentration for 50% growth inhibition: > 100000 nM
Compound 3 was reported as a limit (the forecaster's own chance of this, stated with the estimate: 45%); middle value at least 2.5-fold (0.39 log units) away from the limit.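

Compound 2 and compound 3 both stand only at a limit in this assay, so no step between them can be read: the limit of > 100000 nM in this assay, at which 2 of the 3 values shown sit.

From the compounds shown here alone, what methylamino in place of nitro on an aromatic carbon does to growth inhibition stays open.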